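The source may hold more compounds than are shown below. What is called first, only, known or untested is meant among the compounds shown, and "the series" means these compounds.

Of the compounds shown here, three share one core and have been measured in an assay on isolated protein for displacement of a labelled ligand from metabotropic glutamate receptor 5 (Homo sapiens), with a stated time of 60 min, tested at 1 uM; on this read-out lower numbers stand for less inhibition and higher numbers for more inhibition at the one concentration tested (going by the name of the read-out). Compound 1 `CC1CCN(c2c(S(=O)(=O)c3ccc(F)c(Cl)c3)cnc3cc(Cl)ccc23)CC1` gives 94%. Compound 3 `Cc1ccc(S(=O)(=O)c2cnc3ccc(Cl)cc3c2N2CCC(C)CC2)cc1` gives 95%, and compound 2 `COc1ccc(S(=O)(=O)c2cnc3ccc(Cl)cc3c2N2CCC(C)CC2)cc1Cl` gives 46%. Compound 1 thus stands second highest of the three numbers, within the scatter of compound 3 and well beyond the scatter of compound 2.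

The unmeasured compound 4 `CC1CCN(c2c(S(=O)(=O)c3ccc(Cl)c(Cl)c3)cnc3cc(Cl)ccc23)CC1` differs from compound 1 in one place: chloro in place of fluoro on an aromatic carbon. Cut one bond further out, the change reads 3-chloro-4-fluorophenyl to 3,4-dichlorophenyl on the sulfonyl sulfur.

Among the measured compounds shown here, no measured step exchanges fluoro for chloro, so none bears directly on this change. For the measured compounds named here, the one measured step, a number 49 percentage points higher from compound 2 to compound 3 (beyond the scatter), shows only that the ring on the sulfonyl sulfur can move the read-out by a large amount when a 4-methylphenyl replaces a 3-chloro-4-methoxyphenyl. Since compound 1 already sits near the top of the read-out, little room remains upward, and a single chloro for fluoro exchange is expected to leave the number close to where it is. The step of a number 3 percentage points lower from compound 1 to compound 4 (within the scatter) is therefore expected to stay within the scatter. Compound 4 is estimated at 91%, with a range from 76% to 99%.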

Compound 4, a percentage reported as inhibition, at one concentration (the size of the read-out at that concentration, not a potency): 89%
Compound 4: middle estimate off by 2 percentage points, on the high side, and the stated range covers the measured number.
By their numbers in this assay, from the lowest: compound 2; then compounds 4, 1 and 3 (each within the scatter of the next).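

In this assay, putting chloro in place of fluoro on this aromatic carbon, ortho to a chloro group and para to a large group, gives a number 5 percentage points lower from compound 1 to compound 4 (within the scatter) and so stays inside the normal spread of repeat measurements. The earlier step of a number 49 percentage points higher from compound 2 to compound 3 (beyond the scatter) showed that exchanging one whole ring on the sulfonyl sulfur for another can move the read-out a long way, whereas this result shows that a single halogen exchange at this carbon need not, with 3-chloro-4-fluorophenyl and 3,4-dichlorophenyl not told apart at the one concentration tested. Nothing available here explains why these two halogens give readings so alike.

Compound 2 carries a methoxy group on the corresponding ring but differs from compound 4 in more than one place, so the effect of that group alone on the read-out stays unresolved. Also open, as far as these compounds go, is how this carbon would respond to a group other than a halogen, such as a nitrile, an amine or a carboxylic acid, and whether full concentration-response curves would separate compound 1 from compound 4.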